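The source may hold more compounds than are shown below. What is called first, only, known or untested is meant among the compounds shown, and "the series" means these compounds.

Compound 1 (`Cc1cc(=O)c2c(O)cc(OCc3ccccc3)c([C@H]3CCN(C)C[C@H]3O)c2o1`): 41%
Compound 2 (`Cc1cc(=O)c2c(O)c(CN3CCCC3CO)c(O)c([C@H]3CCN(C)C[C@H]3O)c2o1`): 15%
Compound 3 (`Cc1oc2c([C@H]3CCN(C)C[C@H]3O)c(O)cc(O)c2c(=O)c1C(O)c1cccc(Cl)c1`): 31%

These three compounds were tested in a functional assay on PC-3 cells (Homo sapiens) for inhibition, read by MTT assay, with a stated time of 48 h, tested at 10 uM; a higher number here means more inhibition of growth at the concentration tested, a lower number less inhibition of growth. Compound 3, at 31%, cannot be told apart from compound 1 (41%) because the two values lie within the usual scatter. Compound 2 (15%) lies lower than compound 3, and that gap goes beyond the scatter.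

The next compound to be measured is compound 4 (`Cc1oc2c([C@H]3CCN(C)C[C@H]3O)c(O)cc(O)c2c(=O)c1C(O)c1c(F)cccc1Cl`). It carries 2-chloro-6-fluorophenyl in place of 3-chlorophenyl on a saturated chain carbon bound to an aromatic carbon and an oxygen on a saturated carbon. Both groups hold one six-membered aromatic ring of carbon only, and the rest of the structure stays the same.

Among the measured compounds shown here, no two measured compounds differ in one place, so the data show nothing directly about the size or direction of such a step. The expectation therefore starts from compound 3 at 31% and assumes no shift beyond the scatter in this assay, with neither direction favoured. The expected step, a number 1 percentage points lower from compound 3 to compound 4 (within the scatter), is small. Compound 4 is estimated to give 30% in this assay, with an expected range from 14% to 46% in this read-out.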

Compound 4, percent growth inhibition at one concentration: 0%
The estimate for compound 4 lay 30 percentage points above the measured number; measured number outside the range, below it.
By their numbers in this assay, from the lowest: compound 4; then compound 2; then compounds 3 and 1 (each within the scatter of the next).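

In this assay, among the compounds shown here, replacing 3-chlorophenyl with 2-chloro-6-fluorophenyl on a saturated chain carbon bound to an aromatic carbon and an oxygen on a saturated carbon gives a number 31 percentage points lower from compound 3 to compound 4 (beyond the scatter), the first step in this set that can be read at a single place. The earlier compounds shown here differed from one another in more than one place, whereas this pair shows that growth inhibition responds strongly to the substitution of this aryl group, even though both groups hold one six-membered aromatic ring of carbon only, carry no hydrogen-bond donors or acceptors and have no net charge. Nothing measured here accounts for the size of this step.

The step combines a different chlorine placement with an added fluorine, so this single pair cannot assign the change to either feature, and 2-chlorophenyl, 2-fluorophenyl or unsubstituted phenyl at this place would be needed to separate them. The compounds shown also leave open whether the hydroxy group on the same chain carbon contributes to the response, which a methylene link in its place would test.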